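Removing a fluorine from the sulfonamide ring

The compounds below may be only part of what the source reports. "The series", "measured", "known", "first", "only" and "open" are said of these compounds alone.

Of the compounds shown here, three sharing one core have been tested in a functional assay on KARPAS-422 cells (Homo sapiens) for inhibition, read by CCK-8 assay; a higher number here means a weaker inhibitor of growth, a lower number a stronger inhibitor of growth. Compound 1 `O=S(=O)(Nc1cc(-c2cnc3[nH]cc(-c4ccncc4)c3c2)cnc1Cl)c1ccccc1F` gives 350 nM. Compound 2 `O=S(=O)(Nc1cc(-c2cnc3[nH]nc(-c4ccccc4)c3c2)cnc1Cl)c1ccccc1` gives 1230 nM, and compound 3 `O=S(=O)(Nc1cc(-c2cnc3[nH]nc(-c4ccncc4)c3c2)cnc1Cl)c1ccccc1` gives 170 nM. Among these three numbers compound 1 stands second highest: compound 3 is nearest to it, compound 2 furthest. Going by the values given here, the only single-point step among the measured compounds is a 7.2-fold lower number from compound 2 to compound 3 (0.86 log units; beyond the scatter). Among the compounds with values here, compound 1 and compound 3 differ in their core and are not joined by such a step; their two values show only that compound 3 sits lower than compound 1.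

Compound 4 `O=S(=O)(Nc1cc(-c2cnc3[nH]cc(-c4ccncc4)c3c2)cnc1Cl)c1ccccc1` is not yet measured. It differs from compound 1 in one place: hydrogen in place of fluoro on an aromatic carbon. Within the data shown here, no measured step touches the sulfonamide ring, so the change from compound 2 to compound 3, which replaces phenyl with pyridin-4-yl, does not speak to it directly. Without a guide, a small step is expected in this assay that stays within the scatter, in either direction. Compound 4 is therefore estimated at 400 nM, with a range from 150 nM to 1100 nM. This corresponds to an expected step of a 1.1-fold higher number from compound 1 to compound 4 (0.06 log units; within the scatter).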

Compound 4, concentration for 50% growth inhibition: 120 nM
Compound 4: middle estimate off by 3.3-fold (0.52 log units), on the high side; the measured number lies below the stated range.
By their numbers in this assay, from the lowest: compounds 4 and 3 (each within the scatter of the next); then compound 1; then compound 2.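

In this assay, replacing the fluoro with hydrogen, which turns 2-fluorophenyl into phenyl, gives a 2.9-fold lower number from compound 1 to compound 4 (0.46 log units; beyond the scatter). Going by these compounds alone, this is the first step seen on the sulfonamide ring, and it shows that this position is not silent: a change of a single atom, on an aromatic carbon ortho to a large group, is enough to shift growth inhibition, and here the compound without fluorine is the stronger inhibitor. Nothing available gives a reason for this shift, which stands as an observation of these two compounds only.

Hydrogen and fluoro are the only two groups seen at this place, leaving open whether a chlorine, a methoxy group or an amine there would lower the number further or raise it. Going by these compounds, it is also open whether this change would give a step of similar size on the core of compound 3, and whether a fluoro at other places on this ring would behave in the same way.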